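This account rests on a few compounds, and the source may have more. Where it says the series, first, only, none or still open, it means among the compounds named here.

The measured compounds so far:
- compound 1, `CNC(=O)c1cc(Oc2ccc3nc(NC(=O)Nc4ccc(N5CCN(C)CC5)cc4)sc3c2)ccn1`, which in a functional assay on SK-BR-3 cells (Homo sapiens) for inhibition, read by MTT assay, with a stated time of 2 days, tested at 10 uM (a lower number here means less inhibition of growth, a higher number more inhibition of growth at the concentration tested), gives 30.5%;
- compound 2, `CNC(=O)c1cc(Oc2ccc3nc(NC(=O)Nc4ccc(Cl)cc4)sc3c2)ccn1`, which in this assay gives 50.8%.

Compound 2 stands highest of the two numbers. Within the data shown here, its nearest neighbour is compound 1, and the one step between them, a number 20.3 percentage points higher from compound 1 to compound 2 (beyond the scatter), lies beyond the scatter. Compound 3, `CNC(=O)c1cc(Oc2ccc3nc(NC(=O)Nc4ccc(Cl)cc4Cl)sc3c2)ccn1`, is not yet measured. It differs from compound 2 by chloro in place of hydrogen on an aromatic carbon. No measured step bears directly on this change: the only step shown, a number 20.3 percentage points higher from compound 1 to compound 2 (beyond the scatter), exchanges a different group and says nothing about adding a second chloro to the aryl urea end. The expectation therefore rests on compound 2 alone. A step in this assay beyond the scatter is possible in either direction, but nothing in the two numbers points to one. Compound 3 is expected to give 55%, within a range from 35% to 75%. The step that this estimate means, a number 4.2 percentage points higher from compound 2 to compound 3 (within the scatter), is expected to stay within the scatter.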

Compound 3, percent growth inhibition at one concentration: 22.3%
Compound 3: the middle estimate sits 32.7 percentage points above what was measured; the measured number lies below the stated range.
By their numbers in this assay, from the lowest: compounds 3 and 1 (each within the scatter of the next); then compound 2.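

In this assay, the place on the six-membered aromatic ring that is ortho to a large group and meta to a chloro group proves sensitive to substitution: the change from 4-chlorophenyl to 2,4-dichlorophenyl gives a number 28.5 percentage points lower from compound 2 to compound 3 (beyond the scatter) and so moves the number by more than the usual scatter. The earlier step, a number 20.3 percentage points higher from compound 1 to compound 2 (beyond the scatter), exchanged one group for another, chloro in place of 4-methylpiperazin-1-yl, whereas this change leaves that chloro in place and adds a single chlorine atom, so one added heavy atom is enough to produce a step beyond the scatter. Nothing among the data shown accounts for this drop, and it stands as an observation only.

The compounds shown leave open whether the lower number belongs to chloro itself or would follow any group at this place, which a fluoro, methyl or methoxy group there could settle. They also leave open whether the same added chloro would lower the number with 4-methylpiperazin-1-yl in place of the first chloro.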